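Swapping chloro for bromo on an aromatic ring

A few compounds are considered here, and "the series" means these few. Any claim that something is new, unique, unknown or untested is made for them only; others in the source may bear on it.

Measured in a functional assay on NCI-H1299 cells (Homo sapiens) for cytotoxicity, read by a luciferase reporter and CellTiter-Glo, with a stated time of 72 h; a lower number here means a stronger inhibitor, a higher number a weaker inhibitor
Compound 1 `COc1ccccc1C1=NN(c2ccc(Cl)cc2)C(c2ccc(Cl)cc2)C1` gives "not determined" (no result reported)
Compound 2 `CC(C)(C)C1=NN(c2ccc(Cl)cc2)C(c2ccc(Cl)cc2)C1` gives 19300 nM
Compound 3 `CC(C)(C)C1=NN(c2ccc(Cl)cc2)C(c2ccc(Cl)c(Cl)c2)C1` gives 14800 nM

Compound 1 has no number to compare, which leaves compound 2 with a single numerical neighbour, compound 3, and the two lie within the scatter of each other. Compound 4 `CC(C)(C)C1=NN(c2ccc(Br)cc2)C(c2ccc(Cl)cc2)C1` differs from compound 2 in one place. The change is bromo in place of chloro on an aromatic carbon and, in words, it puts bromo in place of chloro on an aromatic carbon, so that a 4-chlorophenyl becomes a 4-bromophenyl.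

Among the compounds with values here, no measured pair makes this exact exchange, so the evidence is indirect. The closest measured step adds a chloro in place of hydrogen on an aromatic carbon. It gave a 1.3-fold lower number from compound 2 to compound 3 (0.12 log units; within the scatter) and on that evidence no step beyond the scatter is expected in this assay for the new exchange, in either direction. The expected step is a 1.1-fold lower number from compound 2 to compound 4 (0.03 log units; within the scatter) as an estimate from very few data. For compound 4 the estimated value is 18000 nM with an expected range from 9000 nM to 35000 nM when it is measured.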

Compound 4, half-maximal inhibitory concentration: 19400 nM
Compound 4: middle estimate off by 1.1-fold (0.03 log units), on the low side; the range from low to high includes it.
By their numbers in this assay, from the lowest: compounds 3, 2 and 4 (each within the scatter of the next).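

In this assay, the change from 4-chlorophenyl to 4-bromophenyl gives a 1.0-fold higher number from compound 2 to compound 4 (0.00 log units; within the scatter), so this exchange leaves the number within the scatter. Within the data shown here, this is the first view of this position, since the earlier step between measured compounds added a chloro at a different place on the molecule. For this one pair, then, bromo can stand in for chloro on this aromatic carbon without a measurable shift in this cell assay, and nothing measured here offers an explanation for that.

Both halogens are single atoms, so the pair says little about how much this position would respond to a group of a different kind, such as an amine or a carboxylic acid. Going by these compounds, whether the same exchange would also leave the number unmoved on a different core remains open too.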